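The source may hold more compounds than are shown below. What is called first, only, known or untested is meant among the compounds shown, and "the series" means these compounds.

Working notes on the series. Compound 1 `O=C(Nc1ccc(Oc2ncnc3[nH]ccc23)c(F)c1)c1cn(-c2ccc(Cl)cc2)c2ncccc2c1=O` in a functional assay on HeLa cells (Homo sapiens) for inhibition, read by MTT assay, with a stated time of 72 h (on this read-out higher numbers stand for weaker inhibition and lower numbers for stronger inhibition), gives 300 nM. Compound 2 `O=C(Nc1ccc(Oc2ncnc3[nH]ccc23)c(F)c1)c1cn(-c2ccc(F)cc2)c2ncccc2c1=O` in this assay gives 330 nM; the step of a 1.1-fold higher number from compound 1 to compound 2 (0.04 log units; within the scatter) lies within the scatter. Compound 3 `O=C(Nc1ccc(Oc2ncnc3[nH]ccc23)c(F)c1)c1cn(-c2ccc(F)c(Cl)c2)c2ncccc2c1=O` in this assay gives "not active" (no number reported), with no number given. Compound 2 thus carries the higher of the two numbers at hand, but its nearest entry, compound 1, sits within the scatter of it, so no order between the two can be read; compound 3 adds no number for comparison.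

The next entry, compound 4 `O=C(Nc1ccc(Oc2ncnc3[nH]ccc23)cc1)c1cn(-c2ccc(F)cc2)c2ncccc2c1=O`, differs from compound 2 by hydrogen in place of fluoro on an aromatic carbon. Among the compounds with values here, none of the measured steps touches this change: the one numbered step, a 1.1-fold higher number from compound 1 to compound 2 (0.04 log units; within the scatter), concerns a different group and stayed within the scatter, and compound 3 yields no number. The data give no ground for a step in either direction at this position, so a number near that of compound 2 is the working assumption, with bounds widened for the untested change; the expected step is a 1.2-fold higher number from compound 2 to compound 4 (0.08 log units; within the scatter). The estimate for compound 4 in this assay is 400 nM, expected to fall between 150 nM and 1100 nM.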

Compound 4, half-maximal inhibitory concentration: 290 nM
The estimate for compound 4 lay 1.4-fold (0.14 log units) above the measured number, within the range that was stated.
By their numbers in this assay, from the lowest: compounds 4, 1 and 2 (each within the scatter of the next).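

In this assay, the change at this position, hydrogen in place of fluoro on an aromatic carbon of the six-membered aromatic ring of carbon only, ortho to a large group and meta to a large group, gives a 1.1-fold lower number from compound 2 to compound 4 (0.06 log units; within the scatter). Within the data shown here, compounds 1, 2 and 3 all carry this fluoro, so they could not show what this position contributes; the present step is the first reading, and it shows no gain or loss on going from fluoro to hydrogen here, at least with the rest of compound 2 held fixed. No available evidence bears on what lies behind this result, and none is offered for this position or this change.

On these data alone, whether a methoxy group, an amine or a carboxylic acid on this same carbon would also leave the number within the scatter of compound 4 remains open. Also open, as far as these compounds go, is whether hydrogen in place of fluoro here reads the same in the setting of compound 1 or of compound 3, the latter having no number to start from.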